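The compounds below may be only part of what the source reports. "The series", "measured", "known", "first", "only" and "open" are said of these compounds alone.

Measured so far:
compound 1 `CCCn1ncc2c(Nc3ccc(OC(F)(F)F)cc3)ncnc21` — 6600 nM
compound 2 `CCn1ncc2c(Nc3ccc(OC(F)(F)F)cc3)ncnc21` — > 10000 nM

In an ADME assay on BaF3 cells (Mus musculus) for cytotoxicity (on this read-out lower numbers stand for an effect already at smaller amounts and higher numbers for an effect only at larger amounts of compound), compound 1 gives 6600 nM. For compound 2 the assay reports only a limit, > 10000 nM, and no number. Compound 2 therefore stands at the limit of > 10000 nM in this assay, at which 1 of the 2 values shown sits, the upper edge of what this assay resolves. Among the compounds with values here, the one measured step, an at least 1.5-fold higher number from compound 1 to compound 2 (0.18 log units; that floor lies within the scatter), is the only guide available.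

Compound 3 `OCCn1ncc2c(Nc3ccc(OC(F)(F)F)cc3)ncnc21` differs from compound 2 by hydroxy in place of hydrogen on a saturated chain carbon, two bonds along the chain from an aromatic nitrogen: the ethyl of compound 2 becomes 2-hydroxyethyl. Within the data shown here, no measured step involves a hydroxy group, so the step from compound 2 to compound 3 rests on weak ground; given that compound 2 already sits at the limit, no movement beyond the scatter is expected, and a further limit is the most likely outcome. Compound 3 is estimated at 13000 nM, within 5000 nM to 35000 nM, which means an expected step that the limit leaves unreadable from compound 2 to compound 3.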

Compound 3, half-maximal effective concentration: > 10000 nM
Compound 3: only a limit was reported (the forecaster's own chance of this, stated with the estimate: 70%); the middle value lies beyond the limit too.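

In this assay, hydroxy in place of hydrogen on the saturated chain carbon leaves the 2-hydroxyethyl compound 3 at the same edge of the read-out as the ethyl compound 2: the limit of > 10000 nM in this assay, at which 2 of the 3 values shown sit. The step between compound 2 and compound 3 cannot be read, so any effect of this change stays hidden. Within the data shown here, measured against compound 1, the only compound with a number, the result is an at least 1.5-fold higher number from compound 1 to compound 3 (0.18 log units; that floor lies within the scatter) and this floor does not separate the two compounds.

As far as these compounds go, how far compound 2 and compound 3 lie past the limit remains open, as does whether they differ from each other at all. Also open, from the compounds shown here alone, is whether an amine, a carboxylic acid or a longer chain at this place would bring the value back into the readable range.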